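Methyl for Fluorine on the Cyclopropyl Amide

A few compounds are considered here, and "the series" means these few. Any claim that something is new, unique, unknown or untested is made for them only; others in the source may bear on it.

For the measured compounds named here, compound 2 `O=C([C@@H]1C[C@H]1F)N1CC2CC(C1)N2` gives 1 nM in an assay on SH-EP1 cells for displacement of a labelled ligand from Neuronal acetylcholine receptor; alpha4/beta2 (Homo sapiens), read by scintillation counting (a lower number here means a stronger inhibitor, a higher number a weaker inhibitor), the lowest of the two numbers known so far, while compound 1 `O=C([C@H]1C[C@H]1F)N1CC2CC(C1)N2` gives 1.1 nM, within the scatter of that. The next compound, compound 3 `C[C@@H]1C[C@@H]1C(=O)N1CC2CC(C1)N2`, carries a group of 4 heavy atoms (4 carbon; one three-membered non-aromatic ring of carbon only) in place of a group of 4 heavy atoms (3 carbon, 1 fluorine; one three-membered non-aromatic ring of carbon only), on a carbonyl carbon. Going by the values given here, the only measured step, a 1.1-fold lower number from compound 1 to compound 2 (0.04 log units; within the scatter), turns on a stereocentre the fact that one of compounds 1 and 2 is drawn with a defined configuration and the other without, at the place where they differ and says nothing about swapping fluorine for methyl on the three-membered ring. Among the compounds with values here, with no comparable step to lean on, and the groups equal in size, the expectation is little movement, a 2.0-fold higher number from compound 2 to compound 3 (0.30 log units; within the scatter). Compound 3 is therefore expected to give 2 nM, between 0.5 nM and 8 nM.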

Compound 3, inhibition constant: 22 nM
The estimate for compound 3 lay 11-fold (1.04 log units) below the measured number; measured number above the stated range.
By their numbers in this assay, from the lowest: compounds 2 and 1 (each within the scatter of the next); then compound 3.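

Swapping fluoro for methyl on the three-membered ring is far from a neutral exchange, even though both groups count the same heavy atoms: a 22-fold higher number from compound 2 to compound 3 (1.34 log units; beyond the scatter), and a 20-fold higher number from compound 1 to compound 3 (1.30 log units; beyond the scatter). In this assay, this makes compound 3 the weakest of the three, so matching group size alone does not preserve binding at this position. Nothing measured here explains the loss.

Going by these compounds, whether fluoro itself is required remains open, as does where a ring bearing chloro, hydroxyl or a longer chain such as ethyl would fall relative to compound 2 and compound 3.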